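Swapping chloro for tert-butyl on a hydroxamic acid series

This account rests on a few compounds, and the source may have more. Where it says the series, first, only, none or still open, it means among the compounds named here.

Four compounds share a hydroxamic acid arm on a lactam core and differ in the group on a six-membered aromatic ring of carbon only. Compound 1 `O=C(CCC1=CCN(CCCc2ccc(Cl)cc2)C1=O)NO` carries chloro there; in a functional assay on NUGC-3 cells (Homo sapiens) for inhibition, read by sulforhodamine B assay (a higher number here means a weaker inhibitor of growth, a lower number a stronger inhibitor of growth), compound 1 gives 2200 nM. Compound 2 `CC(C)(C)c1ccc(CCCN2CC=C(CCC(=O)NO)C2=O)cc1` instead carries tert-butyl, and compound 2 gives 2200 nM. The change between them, (tert-butyl in place of chloro on an aromatic carbon), produced no change at the digits printed from compound 1 to compound 2 (within the scatter).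

Compound 3 `O=C(CCC1=CCN(Cc2ccc(Cl)cc2)C1=O)NO` also carries chloro, and compound 3 gives 4280 nM. The cores of compound 3 and compound 1 differ in more than one place, and that difference is not broken down here. Compound 4 `CC(C)(C)c1ccc(CN2CC=C(CCC(=O)NO)C2=O)cc1` is not yet measured; it stands to compound 3 as compound 2 stands to compound 1, through (tert-butyl in place of chloro on an aromatic carbon), with the place described in the same words, so this is the same change.

Because no change at the digits printed from compound 1 to compound 2 (within the scatter) showed no shift within the scatter, the expectation for compound 4 is a step of about a 1.0-fold higher number from compound 3 to compound 4 (0.00 log units; within the scatter) from compound 3. Compound 4 is therefore estimated at 4300 nM, plausibly between 2000 nM and 9000 nM.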

Compound 4, concentration for 50% growth inhibition: 720 nM
The estimate for compound 4 lay 6.0-fold (0.78 log units) above the measured number; the measured number lies below the stated range.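

In this assay, the step on the second core is a 5.9-fold lower number from compound 3 to compound 4 (0.77 log units; beyond the scatter), so there tert-butyl in place of chloro goes with a stronger inhibitor of growth. Set beside the earlier step, the same change does not carry over from one core to the other with the same size: the same change on two cores in this assay, no change at the digits printed (within the scatter) from compound 1 to compound 2 and a 5.9-fold lower number (0.77 log units; beyond the scatter) from compound 3 to compound 4, 5.9-fold (0.77 log units) apart, beyond the scatter of two such steps. This shows that the step measured on the core of compound 1 cannot simply be transferred as a number to the core of compound 3, but it does not show why the two cores respond differently, and one pair on each core gives no rule for any other core.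

The compounds shown hold only chloro and tert-butyl at this place, leaving open whether a group such as methoxy or a carboxylic acid would also separate the two cores. Going by these compounds, it also remains open how the same swap would behave on a core with a longer chain.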